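A Basic Ring Amine in Place of a Dioxane Ring

The compounds below may be only part of what the source reports. "The series", "measured", "known", "first", "only" and "open" are said of these compounds alone.

Compound 1, `Cc1cc(C)c(S(=O)(=O)N2CCC(C3OCC(C)CO3)CC2)c(C)c1`, was tested in a functional assay on DLD-1 cells (Homo sapiens) for antiproliferative activity, read by CellTiter-Glo, with a stated time of 72 h; on this read-out lower numbers stand for stronger inhibition and higher numbers for weaker inhibition. In this assay compound 1 gives > 5000 nM, which is a limit of the assay rather than a measured number. Compound 2, `CC1CCN(C2CCN(S(=O)(=O)c3sc(Cl)nc3C3CC3)CC2)CC1`, also reaches only a limit in this assay, at > 5000 nM. Compound 3, `COc1ccc(-c2cccc(S(=O)(=O)N3CCC(N4CCC(C)CC4)CC3)c2)cc1`, gives 23 nM in this assay. Compound 1 therefore stands at the limit of > 5000 nM in this assay, at which 2 of the 3 values shown sit, with no number of its own to compare.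

Compound 4, `Cc1cc(C)c(S(=O)(=O)N2CCC(N3CCN(C)CC3)CC2)c(C)c1`, differs from compound 1 in one place: a group of 7 heavy atoms (5 carbon, 2 nitrogen; one six-membered non-aromatic ring with 2 hetero atoms) in place of a group of 7 heavy atoms (5 carbon, 2 oxygen; one six-membered non-aromatic ring with 2 hetero atoms), on a saturated ring carbon. For the measured compounds named here, no pair of measured compounds isolates this exchange. Compound 3 shows that a basic ring amine on that saturated ring carbon can go together with a value of 23 nM, though its aryl part also differs from that of compound 1. Compound 2, which carries a basic ring amine too, reaches only a limit. The step from compound 1 to compound 4 is expected to be modest, towards stronger inhibition, at an at least 1.6-fold lower number from compound 1 to compound 4 (0.22 log units; that floor lies within the scatter). In this assay compound 4 is estimated at 3000 nM, expected between 500 nM and 10000 nM.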

Compound 4, half-maximal inhibitory concentration: 1100 nM
Compound 4: the middle estimate sits 2.7-fold (0.44 log units) above what was measured, and the stated range covers the measured number.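

Putting 4-methylpiperazin-1-yl in place of the ring with 2 oxygen atoms, on this saturated ring carbon, gives an at least 4.5-fold lower number from compound 1 to compound 4 (0.65 log units; beyond the scatter) in this assay. This is the only step shown that changes one place while the aryl part stays the same, which compound 2 and compound 3 could not offer. The step is only a floor, and its true size is unknown, as compound 1 has no number of its own and stands at a limit: the limit of > 5000 nM in this assay, at which 2 of the 4 values shown sit.

The compounds shown leave open whether the two ring nitrogens are both needed, which a morpholine ring or an open-chain dimethylamino group on the same carbon would test. Also open, going by these compounds, is how much the aryl part contributes, as compound 3 differs from compound 4 in more than one place.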